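Solubility of a quinoline series: from compound 2 to compound 4

This account rests on a few compounds, and the source may have more. Where it says the series, first, only, none or still open, it means among the compounds named here.

Measured compounds:
compound 1, `COc1cccc(CNCCCNc2ccnc3cc(-c4ccc(F)cc4)ccc23)c1O`, 32000 nM
compound 2, `COc1ccc(Oc2ccc3c(NCCCNCc4cc(F)ccc4OC)ccnc3c2)cc1`, 14500 nM
compound 3, `c1ccc(Oc2ccc3c(NCCCNCc4ccco4)ccnc3c2)cc1`, 14500 nM

In a physicochemical assay for solubility, with a stated time of 18 h, at pH 7.4 (a lower number here means a less soluble compound, a higher number a more soluble compound), compound 2 gives 14500 nM. It stands level with compound 3 at the digits shown, and the two together are the lowest of the three numbers; the nearest is compound 3, with no change at the digits shown, and the furthest is compound 1, whose number is higher by a step beyond the scatter.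

Compound 4, `COc1ccc(F)cc1CNCCCNc1ccnc2cc(Oc3cccc(N(C)C)c3)ccc12`, is not yet measured. It differs from compound 2 in one place: 3-(dimethylamino)phenyl in place of 4-methoxyphenyl on an oxygen on an aromatic ring, that is, 3-(dimethylamino)phenoxy in place of 4-methoxyphenoxy. For the measured compounds named here, no pair among the measured compounds shows this change, so no step for it is known. He expects no step beyond the scatter, since both groups carry no donor and one acceptor and bear no charge. In this assay compound 4 is therefore estimated at 15000 nM, between 6000 nM and 40000 nM, a step of a 1.0-fold higher number from compound 2 to compound 4 (0.01 log units; within the scatter).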

Compound 4, solubility: 14500 nM
Beside the measured number, compound 4's estimate is 1.0-fold (0.01 log units) above it, and the stated range covers the measured number.
By their numbers in this assay, from the lowest: compounds 2, 3 and 4 (each within the scatter of the next); then compound 1.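

In this assay, for the compounds shown here, putting 3-(dimethylamino)phenyl in place of 4-methoxyphenyl on the oxygen gives no change at the digits printed from compound 2 to compound 4 (within the scatter), the first step that can be read at this position. Going by these compounds alone, the earlier compounds held no pair differing in one place, so this is the first evidence that this position tolerates this particular exchange without a step beyond the scatter. Nothing measured here offers an explanation for this result.

From the compounds shown here alone, whether a carboxylic acid in place of the dimethylamino group would leave the number level remains open. So does whether this exchange gives the same step when the furan-2-ylmethyl group of compound 3 stands on the chain.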